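The source may report more compounds than this note shows. Statements on the series, on what has been measured and on what is new or still open speak of the compounds shown alone.

Measured so far in a functional assay on Ehrlich cells (Mus musculus) for cytotoxicity, read by trypan blue exclusion, with a stated time of 2 h, tested at 10 ug/mL; a higher number here means a stronger effect of the compound at the concentration tested, a lower number a weaker effect:
compound 1 `N#CC1=C(N)N(c2ccc(S(N)(=O)=O)cc2)C2=C(CCCC2)C1c1ccc(O)cc1` gives 20%;
compound 2 `N#CC1=C(N)N(c2ccc(S(N)(=O)=O)cc2)C2=C(CCCC2)C1c1cccc([N+](=O)[O-])c1` gives 0%.

Among the compounds with values here, compound 2 holds the lowest of the two numbers; its only neighbour is compound 1, and the single measured step ends at compound 2. Compound 3 `N#CC1=C(N)N(c2ccc(S(N)(=O)=O)cc2)C2=C(CCCC2)C1c1ccccc1Cl` has not yet been measured. It differs from compound 2 by 2-chlorophenyl in place of 3-nitrophenyl on a saturated ring carbon. Within the data shown here, no measured step follows this exact change. Among the measured compounds shown here, the only step on record, a number 20 percentage points lower from compound 1 to compound 2 (beyond the scatter), swapped a different group on the same saturated ring carbon, so it shows merely that changes at this spot can shift the number by a modest amount, not in which direction a chlorophenyl group would pull. Since compound 2 already sits at the floor of the scale, the number for compound 3 cannot drop further, and nothing in the data argues for a large rise. The expected step for compound 3 is therefore small, a number 10 percentage points higher from compound 2 to compound 3 (within the scatter), upward if anything and close to the scatter. Compound 3 is estimated at 10%, with a range from 0% to 25%.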

Compound 3, a percentage reported as activity, at one concentration (the size of the read-out at that concentration, not a potency): 0%
Estimate against measurement, compound 3: 10 percentage points above, and the stated range covers the measured number.
By their numbers in this assay, from the lowest: compounds 2 and 3 (each within the scatter of the next); then compound 1.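

In this assay, putting 2-chlorophenyl in place of 3-nitrophenyl on the saturated ring carbon gives no change at the digits printed from compound 2 to compound 3 (within the scatter) and so two different substituted phenyl groups at this spot now give the same reading at the bottom of the scale. Against the 4-hydroxyphenyl group, the new compound shows a number 20 percentage points lower from compound 1 to compound 3 (beyond the scatter) and this matches the drop already seen with 3-nitrophenyl, so among these three compounds only compound 1 gives a reading clearly above the others. Nothing on hand accounts for this difference between the groups.

With compound 2 and compound 3 both at the bottom of the scale, this single concentration cannot separate them, and one active compound cannot show whether the hydroxyl group itself or some other feature of the 4-hydroxyphenyl group sets it apart. Going by these compounds, a 4-methoxyphenyl or 4-aminophenyl group, or a plain phenyl ring, on the same carbon would test that more directly, and it also remains open whether moving the chlorine around the ring would change the reading.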